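This account rests on a few compounds, and the source may have more. Where it says the series, first, only, none or still open, it means among the compounds named here.

Compounds sharing one core and differing only in the group on an aromatic nitrogen have been tested in a functional assay on HeLa cells (Homo sapiens) for cytotoxicity, read by MTT assay, with a stated time of 72 h; on this read-out lower numbers stand for stronger inhibition and higher numbers for weaker inhibition. Here compound 1 `O=C(Nc1ccc(Oc2ncnc3[nH]ccc23)c(F)c1)c1cc2cccnc2n(-c2ccccc2)c1=O` gives 36900 nM, compound 2 `O=C(Nc1ccc(Oc2ncnc3[nH]ccc23)c(F)c1)c1cc2cccnc2n(-c2ccc(Cl)cc2)c1=O` gives 23900 nM and compound 3 `O=C(Nc1ccc(Oc2ncnc3[nH]ccc23)c(F)c1)c1cc2cccnc2n(-c2ccc(Br)cc2F)c1=O` gives 87800 nM. Compound 3 therefore has the highest number of the three, which makes it the weakest.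

Compound 4 `O=C(Nc1ccc(Oc2ncnc3[nH]ccc23)c(F)c1)c1cc2cccnc2n(-c2ccc(C(F)(F)F)cc2Cl)c1=O` has not yet been measured. It carries 2-chloro-4-(trifluoromethyl)phenyl in place of the 4-bromo-2-fluorophenyl of compound 3, on the same aromatic nitrogen: 2-chloro-4-(trifluoromethyl)phenyl in place of 4-bromo-2-fluorophenyl on an aromatic nitrogen.

Three measured steps at this place bear on the change. They are a 1.5-fold lower number from compound 1 to compound 2 (0.19 log units; within the scatter), a 2.4-fold higher number from compound 1 to compound 3 (0.38 log units; beyond the scatter) and a 3.7-fold higher number from compound 2 to compound 3 (0.57 log units; beyond the scatter). All three are small, so among these compounds this group has moved the number only a little. None of them carries the entering group, so the data give no direct guide to it.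

Compound 3, at 87800 nM, sits at the top of the measured span, so a small drop is the likelier direction, possibly one that stays within the scatter. In this assay the expected step is a 1.6-fold lower number from compound 3 to compound 4 (0.20 log units; within the scatter). The estimate for compound 4 is 55000 nM, with an expected range from 22000 nM to 120000 nM.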

Compound 4, half-maximal inhibitory concentration: 96800 nM
Compound 4: middle estimate off by 1.8-fold (0.25 log units), on the low side, and the stated range covers the measured number.
By their numbers in this assay, from the lowest: compounds 2 and 1 (each within the scatter of the next); then compounds 3 and 4 (each within the scatter of the next).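

Putting 2-chloro-4-(trifluoromethyl)phenyl in place of 4-bromo-2-fluorophenyl on the aromatic nitrogen gives a 1.1-fold higher number from compound 3 to compound 4 (0.04 log units; within the scatter) in this assay, so these two groups cannot be told apart in this assay, even though the entering group has more heavy atoms. Among these compounds, compound 4 also stands clear of the two compounds with simpler groups, with a 4.1-fold higher number from compound 2 to compound 4 (0.61 log units; beyond the scatter) and a 2.6-fold higher number from compound 1 to compound 4 (0.42 log units; beyond the scatter), so the four compounds fall into two pairs: compounds 1 and 2 at the lower numbers, and compounds 3 and 4, whose groups each carry two substituents on the phenyl ring, at the higher numbers, with no compound here going against this split. No measurement shown here accounts for this split.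

The compounds shown do not reveal which of the two substituents in compound 3 or compound 4 goes with the higher numbers, since neither substituent is seen alone at its own place on the ring. They also leave open what a methoxy group, an amine or a carboxylic acid on the phenyl ring would do, or a cyclohexyl ring in place of the phenyl.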